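From methylcarbamoyl to hydroxycarbamoyl at a chain end

The source may hold more compounds than are shown below. What is called first, only, known or untested is meant among the compounds shown, and "the series" means these compounds.

Among the measured compounds shown here, in a functional assay on Huh-7 cells (Homo sapiens) for inhibition, read by MTT assay, with a stated time of 72 h (on this read-out lower numbers stand for stronger inhibition and higher numbers for weaker inhibition), compound 2 `CNC(=O)CCCCCCCn1nc(-c2ccc3oc(N)nc3c2)c2c(N)ncnc21` gives 2770 nM as the lower of the two numbers so far. Compound 1 `Nc1ncnc2c1c(-c1cnc3[nH]ccc3c1)nn2CCCCCCC(=O)NO` gives 50900 nM on the same read-out, a gap beyond the usual scatter, so compound 2 is the stronger inhibitor of the pair.

Compound 3 `Nc1nc2cc(-c3nn(CCCCCCC(=O)NO)c4ncnc(N)c34)ccc2o1` shares the core of compound 2 and differs at the end of the chain (hydroxycarbamoyl in place of (methylcarbamoyl)methyl on a saturated chain carbon, six bonds along the chain from an aromatic nitrogen), with hydroxycarbamoyl in place of (methylcarbamoyl)methyl on a saturated chain carbon, six bonds along the chain from an aromatic nitrogen.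

For the measured compounds named here, no measured pair isolates this change, so any forecast is a judgement. Compound 1 also ends in hydroxycarbamoyl, and its 50900 nM on this read-out warns that the group does not by itself bring a low number. The core of compound 1 is a different one, however, so the better starting point is compound 2 with its 2770 nM as the reference. The expected move is toward stronger inhibition, and the estimate is a 4.0-fold lower number from compound 2 to compound 3 (0.60 log units; beyond the scatter) as a modest step beyond the scatter. For compound 3 the estimated value in this assay is 700 nM with an expected range from 120 nM to 4000 nM across repeat measurements.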

Compound 3, half-maximal inhibitory concentration: 5710 nM
Estimate against measurement, compound 3: 8.2-fold (0.91 log units) below, outside the stated range (above it).
By their numbers in this assay, from the lowest: compound 2; then compound 3; then compound 1.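

On the shared core in this assay, hydroxycarbamoyl in place of (methylcarbamoyl)methyl on a saturated chain carbon, six bonds along the chain from an aromatic nitrogen, gives a 2.1-fold higher number from compound 2 to compound 3 (0.31 log units; beyond the scatter), so at this position the change weakens inhibition by a modest step rather than strengthening it. With hydroxycarbamoyl at the chain end in both compounds, exchanging the two-ring aromatic group on an aromatic carbon gives an 8.9-fold lower number from compound 1 to compound 3 (0.95 log units; beyond the scatter), which shows that the number for a compound ending in hydroxycarbamoyl shifts with the group carried at that other place. No measurement shown here gives a reason for either step.

On these data alone, the chain-end change is seen in a single pair, so whether the same step would appear on the core of compound 1 remains open. Also open, as far as these compounds go, is how a carboxylic acid or a primary amide at the chain end would compare with compound 2 and compound 3, and whether a longer chain would alter the step between hydroxycarbamoyl and (methylcarbamoyl)methyl.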